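Aryl carbinol variation on the shared core: compound 4 outlook

The source may hold more compounds than are shown below. What is called first, only, known or untested is meant among the compounds shown, and "the series" means these compounds.

Measured so far:
compound 1 `Cc1cc(=O)c2c(O)c(CN3CC(O)CC3C(=O)O)c(O)c([C@H]3CCN(C)C[C@H]3O)c2o1`, 19%
compound 2 `Cc1cc(=O)c2c(O)c(CN3CCCCC3)c(O)c([C@H]3CCN(C)C[C@H]3O)c2o1`, 22%
compound 3 `Cc1oc2c([C@H]3CCN(C)C[C@H]3O)c(O)cc(O)c2c(=O)c1C(O)c1ccc(Cl)cc1`, 3%

In a functional assay on Caco-2 cells (Homo sapiens) for inhibition, read by MTT assay, with a stated time of 48 h, tested at 10 uM (a lower number here means less inhibition of growth, a higher number more inhibition of growth at the concentration tested), compound 3 stands lowest of the three numbers. Its nearest neighbour is compound 1, which gives 19%, a gap beyond the scatter; furthest is compound 2, which gives 22%, also beyond the scatter. Going by the values given here, the only step measured in one place is a number 3 percentage points higher from compound 1 to compound 2 (within the scatter), within the scatter, and it concerns the amine on the saturated chain carbon bound to an aromatic carbon, not the aryl carbinol that distinguishes compound 3.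

Compound 4 `CCOc1ccc(Br)c(C(O)c2c(C)oc3c([C@H]4CCN(C)C[C@H]4O)c(O)cc(O)c3c2=O)c1` is not yet measured. It differs from compound 3 as follows: 2-bromo-5-ethoxyphenyl in place of 4-chlorophenyl on a saturated chain carbon bound to an aromatic carbon and an oxygen on a saturated carbon. Among the compounds with values here, no measured step touches the aryl group on this carbinol carbon, so nothing in hand speaks to the size or direction of the change. Within the data shown here, the one step that does exist was within the scatter. The expectation is therefore a step of no more than the scatter for a number 5 percentage points higher from compound 3 to compound 4 (within the scatter), direction undetermined. Compound 4 is estimated at 8%, with a range from 0% to 25%.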

Compound 4, percent growth inhibition at one concentration: 5%
Beside the measured number, compound 4's estimate is 3 percentage points above it, and the stated range covers the measured number.
By their numbers in this assay, from the lowest: compounds 3 and 4 (each within the scatter of the next); then compounds 1 and 2 (each within the scatter of the next).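

In this assay the aryl group on the carbinol carbon has its first measured step, which is a number 2 percentage points higher from compound 3 to compound 4 (within the scatter) on exchanging 4-chlorophenyl for 2-bromo-5-ethoxyphenyl. The entering group has 10 heavy atoms against 7 in the group it replaces and adds a hydrogen-bond acceptor, yet the two compounds are not separated in this assay, so this position tolerates this particular exchange without a change beyond the scatter. No measurement in hand bears on why the number holds across this exchange.

The bromine and the ethoxy group enter together, and the compounds shown do not separate their contributions, which could be opposed or could both be negligible. Also open, as far as these compounds go, is what an amine or a carboxylic acid on the aryl ring, or a longer chain in place of the ethoxy group, would give in this assay on this same saturated chain carbon.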